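A few compounds are considered here, and "the series" means these few. Any claim that something is new, unique, unknown or untested is made for them only; others in the source may bear on it.

For the measured compounds named here, the compounds here are tested in a functional assay on HeLa cells (Homo sapiens) for antiproliferative activity, read by MTT assay, with a stated time of 48 h (on this read-out lower numbers stand for stronger inhibition and higher numbers for weaker inhibition), and only one of the three measured so far gives a definite number. Compound 1 `Cn1cc(-c2cnc3ccnc(N)c3c2)cn1` is that one: in this assay compound 1 gives 40800 nM. Compound 2 `Cn1cc(-c2cnc3ccc(NC(=O)c4cccnc4)nc3c2)cn1` carries a (pyridin-3-yl)carbonyl group on a ring nitrogen of a differently arranged core; in this assay compound 2 reaches only a limit of the assay, > 50000 nM. Compound 3 `Cn1cc(-c2cnc3ccc(NS(=O)(=O)c4ccc(C(F)(F)F)cc4)nc3c2)cn1` bears a different, larger group on the same kind of nitrogen and likewise gives only a limit in this assay, > 50000 nM. So compound 1 stands alone with a number, while the limit of > 50000 nM in this assay, at which 2 of the 3 values shown sit, marks where the other two sit. Going by the values given here, no pair of measured compounds differs in a single place, so no measured step is available to lean on.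

Compound 4 `Cn1cc(-c2cnc3ccnc(NC(=O)c4cccnc4)c3c2)cn1` is not yet measured. It differs from compound 1 by (pyridin-3-yl)carbonyl in place of hydrogen on a nitrogen on an aromatic ring. The same group on a related core, in compound 2, did not bring a measurable number. With that in view, the expected step is a 1.3-fold higher number from compound 1 to compound 4 (0.13 log units; within the scatter), toward weaker inhibition or no change beyond the scatter. Compound 4 is accordingly estimated at 55000 nM in this assay, with a range from 15000 nM to 200000 nM.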

Compound 4, half-maximal inhibitory concentration: > 50000 nM
Compound 4 was reported as a limit (the forecaster's own chance of this, stated with the estimate: 60%); the middle value is on the limit's open side.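

In this assay compound 4 gives > 50000 nM, which is a limit of the assay and not a number. For the compounds shown here, this is the first comparison here between compounds that differ in one place, and it reads as an at least 1.2-fold higher number from compound 1 to compound 4 (0.08 log units; that floor lies within the scatter) for putting (pyridin-3-yl)carbonyl in place of hydrogen on the nitrogen of compound 1, so this group on this nitrogen brings no measurable gain in inhibition, though the true size of the step stays unknown and may be small or large. Going by these compounds alone, with compound 4, the same group has now failed to give a definite number on two related cores, and the values shown crowd against one limit, leaving compound 1 as the only definite number: the limit of > 50000 nM in this assay, at which 3 of the 4 values shown sit.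

The compounds shown leave open whether a smaller group on the same nitrogen, such as acetyl or methyl, would keep a definite number or improve on compound 1. They also leave open whether a basic amine or a carboxylic acid carried on a longer chain at this nitrogen would move the number in either direction.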